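Hydroxy in Place of Hydrogen: What to Expect for Compound 4

A few compounds are considered here, and "the series" means these few. Any claim that something is new, unique, unknown or untested is made for them only; others in the source may bear on it.

In a functional assay on the whole organism (strain Wistar) for inhibition, with Rattus norvegicus as the target, read by paw edema, with stated times of 30 min and 5 h, at a dose of 20 mg/kg by the oral route (on this read-out higher numbers stand for more inhibition at the one dose given (going by the name of the read-out) and lower numbers for less inhibition), three compounds have been measured:

Compound 1 `Cc1cc(O)c(C2=NN(c3ccc(S(N)(=O)=O)cc3)C(c3ccccc3)C2)cc1Cl` gives 60.3%
Compound 2 `Cc1cc(O)c(C2=NN(c3ccc(S(N)(=O)=O)cc3)C(c3ccccc3O)C2)cc1Cl` gives 59.5%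
Compound 3 `COc1cc(C)c(Cl)cc1C1=NN(c2ccc(S(N)(=O)=O)cc2)C(c2ccccc2)C1` gives 59.5%

Compound 2 differs from compound 1 by hydroxy in place of hydrogen on an aromatic carbon, and that change gave a number 0.8 percentage points lower from compound 1 to compound 2 (within the scatter). Compound 3 has a different core from compound 1, the difference being (methyl in place of hydrogen on an oxygen on an aromatic ring); the two values lie within the scatter of each other, as do those of compound 2 and compound 3.

Compound 4 `COc1cc(C)c(Cl)cc1C1=NN(c2ccc(S(N)(=O)=O)cc2)C(c2cccc(O)c2)C1` has not yet been measured in this assay. It differs from compound 3 by hydroxy in place of hydrogen on an aromatic carbon. This is the same kind of change as that from compound 1 to compound 2, but not the same one: in compound 2 the hydroxy sits ortho to a large group, in compound 4 it sits meta to a large group. With that single precedent, the step from compound 3 to compound 4 is expected to be a number 0.5 percentage points lower from compound 3 to compound 4 (within the scatter), resting on a number 0.8 percentage points lower from compound 1 to compound 2 (within the scatter), which stayed within the scatter. Compound 4 is therefore estimated at 59%, with a range from 48% to 70%.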

Compound 4, a percentage reported as inhibition, in the whole organism at one dose (the size of the read-out at that dose, not a potency): 16.7%
Beside the measured number, compound 4's estimate is 42.3 percentage points above it; measured number below the stated range.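

In this assay, the hydroxy did not carry over as a change of little consequence, the new result being a number 42.8 percentage points lower from compound 3 to compound 4 (beyond the scatter). Set side by side, the two steps do not agree: the same change on two cores in this assay, a number 0.8 percentage points lower (within the scatter) from compound 1 to compound 2 and a number 42.8 percentage points lower (beyond the scatter) from compound 3 to compound 4, 42 percentage points apart, beyond the scatter of two such steps. Among the compounds shown here, this shows that the small step seen on the core of compound 1 cannot be assumed for the core of compound 3, but it does not show that the core alone decides the outcome: the hydroxy in compound 4 sits meta to a large group, in a different place from the one it holds in compound 2, and these two pairs cannot separate core from place.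

The compounds shown leave open what the hydroxy would do on the core of compound 3 in the place it holds in compound 2, and how a 3-hydroxyphenyl would read on the core of compound 1. They also leave open how an amine or a carboxylic acid would read in the place the hydroxy holds in compound 4.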